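Isopropyl to Cyano on the Aromatic Ring of Compound 2

A few compounds are considered here, and "the series" means these few. Any claim that something is new, unique, unknown or untested is made for them only; others in the source may bear on it.

Compound 1, `CSc1ccc(COCC#CC(O)c2ccc(F)cc2)cc1`, gives 20000 nM in a functional assay on MDA-MB-231 cells (Homo sapiens) for inhibition, read by MTT assay, with a stated time of 48 h; a higher number here means a weaker inhibitor of growth, a lower number a stronger inhibitor of growth.
Compound 2, `CSc1ccc(COCC#CC(O)c2ccc(C(C)C)cc2)cc1`, gives 15000 nM in this assay.

Among the measured compounds shown here, compound 2 holds the lower of the two numbers, but its only neighbour, compound 1, sits within the scatter of it, so the two cannot be ordered. Compound 3, `CSc1ccc(COCC#CC(O)c2ccc(C#N)cc2)cc1`, has not yet been measured in this assay. It differs from compound 2 by cyano in place of isopropyl on an aromatic carbon. For the measured compounds named here, the one measured step that bears on this change, which likewise exchanges one group on an aromatic carbon for another, is a 1.3-fold lower number from compound 1 to compound 2 (0.12 log units; within the scatter), and it did not rise above the scatter. On that basis no step beyond the scatter is expected for compound 3, and its number in this assay is estimated at 17000 nM, with a range from 7000 nM to 40000 nM. This estimate implies a 1.1-fold higher number from compound 2 to compound 3 (0.05 log units; within the scatter), which is expected to stay within the scatter.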

Compound 3, concentration for 50% growth inhibition: 62000 nM
For compound 3 the middle estimate is 3.6-fold (0.56 log units) below the measured one, outside the stated range (above it).
By their numbers in this assay, from the lowest: compounds 2 and 1 (each within the scatter of the next); then compound 3.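

In this assay, among the compounds shown here, cyano brings a 4.1-fold higher number from compound 2 to compound 3 (0.62 log units; beyond the scatter) and a 3.1-fold higher number from compound 1 to compound 3 (0.49 log units; beyond the scatter) and these are the first steps at this position to rise above the scatter. The position, para to a large group, is therefore not indifferent to what it carries: fluoro and isopropyl could not be ordered, yet cyano stands apart from both, though only modestly. The compounds shown offer no independent measurement that would account for this difference.

Three groups at one place cannot show whether the higher number is particular to cyano or shared by other groups. From the compounds shown here alone, how an amine, a carboxylic acid or a methoxy group would compare at this place remains open, as does whether any group here could move the number lower than fluoro and isopropyl do.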